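The source may report more compounds than this note shows. Statements on the series, on what has been measured and on what is new or still open speak of the compounds shown alone.

Measured compounds:
- compound 1, `O=C1NC(=O)c2c(NCc3ccccc3[N+](=O)[O-])cccc21`: 25%
- compound 2, `O=C1NCc2c(NCc3ccccc3[N+](=O)[O-])cccc21`: 29%
- compound 3, `O=[N+]([O-])c1cccc(CNc2cc(Br)cc3[nH]ncc23)c1`: 97%

The three compounds were tested in an assay for inhibition of Tryptophan 2,3-dioxygenase (Homo sapiens), with stated times of 10 min and 60 min, tested at 100 uM; on this read-out higher numbers stand for a stronger effect at the one concentration tested and lower numbers for a weaker effect. Compound 1 gives 25% in this assay, and compound 2 gives 29%, two numbers within the usual scatter of each other. Compound 3 stands apart: in this assay compound 3 gives 97%, the highest of the three numbers, and the gap to compound 2 and to compound 1 lies beyond the scatter in both cases. Going by the values given here, no single-point step between measured compounds is available, so no measured step size serves as a guide.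

The untested compound 4, `O=[N+]([O-])c1cccc(CNc2cc(C(F)(F)F)cc3[nH]ncc23)c1`, differs from compound 3 in one place: trifluoromethyl in place of bromo on an aromatic carbon. The change sits on an aromatic carbon of the six-membered carbon ring of the fused system, meta to a fused ring and para to a fused ring. With nothing measured for this kind of exchange, the account expects the step from compound 3 to compound 4 to be small, a number 7 percentage points lower from compound 3 to compound 4 (within the scatter), and because compound 3 already gives 97% there is more room to fall than to rise. Compound 4 is estimated at 90% in this assay, with a range from 70% to 99%.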

Compound 4, a percentage reported as inhibition, at one concentration (the size of the read-out at that concentration, not a potency): 82%
Estimate against measurement, compound 4: 8 percentage points above, and the stated range covers the measured number.
By their numbers in this assay, from the lowest: compounds 1 and 2 (each within the scatter of the next); then compound 4; then compound 3.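

In this assay, going by these compounds alone, the exchange of bromo for trifluoromethyl on this aromatic carbon, meta to a fused ring and para to a fused ring, gives the first measured single-place step (a number 15 percentage points lower from compound 3 to compound 4 (beyond the scatter)), and it shows that the number responds to the group at this position. Even so, compound 4 gives 82% in this assay, so a group of 4 heavy atoms in place of a single bromine leaves a high reading with only a modest step down. No measurement shown bears on the reason for this step.

The compounds shown leave open how a chloro, a methyl, a nitrile or an amine at this same carbon would read in this assay, and one exchange alone sets no trend for the position. They also leave open whether the same exchange would give a step of similar size with a different group in place of the nitro group on the benzyl ring, and a reading at one concentration does not give the potency of either compound.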